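Removing a chloro group from two related glucose derivatives

This account rests on a few compounds, and the source may have more. Where it says the series, first, only, none or still open, it means among the compounds named here.

Of the compounds shown here, three built on a shared sugar core have been tested in an assay for inhibition of glucose-6-phosphatase catalytic subunit 1 (Rattus norvegicus), tested at 100 uM; a higher number here means more inhibition at the concentration tested (going by the name of the read-out), a lower number less inhibition. Compound 1 `CCOC(=O)C(C(=O)OCC)C(CC(=O)C[C@@H]1O[C@H](CO)[C@@H](O)[C@H](O)[C@H]1O)c1ccc(Cl)cc1` gives -6% in this assay. Compound 2 `O=C(/C=C/c1ccc(Cl)cc1)C[C@@H]1O[C@H](CO)[C@@H](O)[C@H](O)[C@H]1O` gives -25.3%, and compound 3 `O=C(/C=C/c1ccccc1)C[C@@H]1O[C@H](CO)[C@@H](O)[C@H](O)[C@H]1O` gives -49.7%. Compound 1 stands highest of the three, and its difference from compound 2 is not broken down here.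

Compounds 2 and 3 differ by one change, (hydrogen in place of chloro on an aromatic carbon), which gave a number 24.4 percentage points lower from compound 2 to compound 3 (beyond the scatter). The same kind of change, (hydrogen in place of chloro on an aromatic carbon), turns compound 1 into compound 4 `CCOC(=O)C(C(=O)OCC)C(CC(=O)C[C@@H]1O[C@H](CO)[C@@H](O)[C@H](O)[C@H]1O)c1ccccc1`, which has not yet been measured in this assay. The surroundings of the place are described in the same words for both pairs, so the step already seen offers a guide. On that basis, compound 4 is expected to show a step of about a number 22 percentage points lower from compound 1 to compound 4 (beyond the scatter), resting on the step from compound 2 to compound 3 and on the value of compound 1, -6%. The estimate for compound 4 in this assay is therefore -28%, with a likely range from -60% to 2%.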

Compound 4, a percentage reported as inhibition, at one concentration (the size of the read-out at that concentration, not a potency): -3.3%
The estimate for compound 4 lay 24.7 percentage points below the measured number, within the range that was stated.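

In this assay, replacing 4-chlorophenyl with phenyl on the core of compound 1 gave a number 2.7 percentage points higher from compound 1 to compound 4 (within the scatter), so this change left no readable mark on that core. Set beside the step on the other core, the result does not match: the same change on two cores in this assay, a number 24.4 percentage points lower (beyond the scatter) from compound 2 to compound 3 and a number 2.7 percentage points higher (within the scatter) from compound 1 to compound 4, 27.1 percentage points apart, beyond the scatter of two such steps

This shows that a step seen on one core in this series is not a safe guide to the same change on another, but two pairs cannot show how general that is or why the cores part ways, and these readings at a single concentration are not potencies.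

The compounds shown leave open whether a fluoro group, a methoxy group or an amine in the same place on the ring would also give different steps on the two cores. They also leave open which part of the core of compound 1 matters, and analogues with carboxylic acids in place of the ethyl esters, or with a shorter chain, would bear on this.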